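The compounds below may be only part of what the source reports. "The series", "measured", "known", "first", "only" and "open" are said of these compounds alone.

Compound 3 `N#CC1=C(N)Oc2c(N)cc3nc4ccccc4nc3c2C12C(=O)N(Cc1cnnn1-c1ccccc1Cl)c1ccccc12` gives 33500 nM in a functional assay on HepG2 cells (Homo sapiens) for antiproliferative activity, read by MTT assay, with a stated time of 48 h; a lower number here means a stronger inhibitor, a higher number a weaker inhibitor. Compound 1 `N#CC1=C(N)Oc2c(c3nc4ccccc4nc3c3ccccc23)C12C(=O)N(Cc1cnnn1-c1cccc(S(N)(=O)=O)c1)c1ccccc12` gives 21500 nM in this assay, so compound 3 and compound 1 sit within the scatter of each other. Compound 2 `Cc1ccc(-n2nncc2CN2C(=O)C3(C(C#N)=C(N)Oc4c3c3nc5ccccc5nc3c3ccccc43)c3ccccc32)cc1C` reaches only the limit > 50000 nM in this assay. Within the data shown here, the one measured step on the aromatic nitrogen, 3,4-dimethylphenyl in place of 3-sulfamoylphenyl, gave an at least 2.3-fold higher number from compound 1 to compound 2 (0.36 log units; beyond the scatter), with compound 2 sitting at the limit of > 50000 nM in this assay, at which 1 of the 3 values shown sits. Compound 4 `Cc1cc(C)cc(-n2nncc2CN2C(=O)C3(C(C#N)=C(N)Oc4c(N)cc5nc6ccccc6nc5c43)c3ccccc32)c1` is not yet measured; it differs from compound 3 by 3,5-dimethylphenyl in place of 2-chlorophenyl on an aromatic nitrogen. Among the measured compounds shown here, that change resembles the one measured step, a dimethylphenyl entering on the aromatic nitrogen, so for compound 4 a weakening step toward the limit is expected, a 1.8-fold higher number from compound 3 to compound 4 (0.25 log units; within the scatter). Compound 4 is therefore estimated at 60000 nM, between 25000 nM and 150000 nM, in this assay.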

Compound 4, half-maximal inhibitory concentration: > 50000 nM
Compound 4: a limit, no number; the forecaster's own chance of this, stated with the estimate: 55%; the middle value does not contradict the limit.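

Replacing 2-chlorophenyl with 3,5-dimethylphenyl gave an at least 1.4-fold higher number from compound 3 to compound 4 (0.17 log units; that floor lies within the scatter) in this assay, so this step on the aromatic nitrogen is bounded on one side only and shows no change beyond the scatter. The earlier dimethylphenyl result came from a different core, and a dimethylphenyl at this position now also appears on the core of compound 3. Compound 2 and compound 4 both give a limit rather than a number: the limit of > 50000 nM in this assay, at which 2 of the 4 values shown sit.

Going by these compounds, how far either compound lies past that limit remains open. So does the effect of an amine or a carboxylic acid on this phenyl ring.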